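Aryl swap on the triazole series: what compound 4 should give

The source may report more compounds than this note shows. Statements on the series, on what has been measured and on what is new or still open speak of the compounds shown alone.

Compound 1, `COc1ccc(-n2c(CCc3ccccc3)nnc2[C@H](NC(=O)c2ccccn2)c2c[nH]c3ccccc23)c(OC)c1`, in an in vitro assay on LLC-PK1 cells for displacement of a labelled ligand from growth hormone secretagogue receptor type 1 (Homo sapiens) (a higher number here means a weaker inhibitor, a lower number a stronger inhibitor), compound 1 gives 33 nM.
Compound 2, `CCc1ccc(Cn2c(CCc3ccccc3)nnc2[C@H](NC(=O)c2ccccn2)c2c[nH]c3ccccc23)cc1`, in this assay compound 2 gives 67 nM.
Compound 3, `CCc1ccc(Cn2c(CCc3ccccc3)nnc2[C@H](NC(=O)c2cnccn2)c2c[nH]c3ccccc23)cc1`, in this assay compound 3 gives 89 nM.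

Compound 4, `COc1ccc(-n2c(CCc3ccccc3)nnc2[C@H](NC(=O)c2cnccn2)c2c[nH]c3ccccc23)c(OC)c1`, has not been measured. It stands to compound 3 as compound 1 stands to compound 2. The difference between the cores of compound 2 and compound 3 is pyrazin-2-yl in place of pyridin-2-yl on a carbonyl carbon, and this gave a 1.3-fold higher number from compound 2 to compound 3 (0.12 log units; within the scatter), a step that stays within the scatter. The change from compound 2 to compound 1 is 2,4-dimethoxyphenyl in place of 4-ethylbenzyl on an aromatic nitrogen, which gave a 2.0-fold lower number from compound 2 to compound 1 (0.31 log units; beyond the scatter). Within the data shown here, the change from compound 3 to compound 4 is 2,4-dimethoxyphenyl in place of 4-ethylbenzyl on an aromatic nitrogen, the same change made at the same place of the shared core, so the earlier step is the only guide to its size. The expectation for compound 4 is a step of a 2.0-fold lower number from compound 3 to compound 4 (0.30 log units; within the scatter), close to the earlier one, because a 2.0-fold lower number from compound 2 to compound 1 (0.31 log units; beyond the scatter) was measured on a core that differs only by the pyrazin-2-yl for pyridin-2-yl change. Compound 4 is therefore estimated at 45 nM in this assay, with a likely range from 22 nM to 90 nM, the width reflecting that the expectation rests on a single earlier pair.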

Compound 4, half-maximal inhibitory concentration: 300 nM
Compound 4: middle estimate off by 6.7-fold (0.82 log units), on the low side; the whole stated range lies below it.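

In this assay, 2,4-dimethoxyphenyl in place of 4-ethylbenzyl gave a 3.4-fold higher number from compound 3 to compound 4 (0.53 log units; beyond the scatter), so the change did not carry over from the core of compound 2 to the core of compound 3, even in direction: the same change on two cores in this assay, a 2.0-fold lower number (0.31 log units; beyond the scatter) from compound 2 to compound 1 and a 3.4-fold higher number (0.53 log units; beyond the scatter) from compound 3 to compound 4, 6.8-fold (0.84 log units) apart, beyond the scatter of two such steps. Read the other way, pyrazin-2-yl in place of pyridin-2-yl gave a 9.1-fold higher number from compound 1 to compound 4 (0.96 log units; beyond the scatter), so the size of that change depends on the group on the aromatic nitrogen: the same change on two cores in this assay, a 1.3-fold higher number (0.12 log units; within the scatter) from compound 2 to compound 3 and a 9.1-fold higher number (0.96 log units; beyond the scatter) from compound 1 to compound 4, 6.8-fold (0.84 log units) apart, beyond the scatter of two such steps. These four compounds show that the two changes do not add up in this case, but they do not show why, and they cannot say how general this is across the series.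

From the compounds shown here alone, it remains open whether 2,4-dimethoxybenzyl on the aromatic nitrogen would behave like 2,4-dimethoxyphenyl or like 4-ethylbenzyl when paired with each carbonyl group. Going by these compounds, it is also open whether a phenyl or pyrimidin-2-yl on the carbonyl carbon would show the same dependence on the group at the aromatic nitrogen.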